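Removing a Methyl from an Aryl Methoxy Group

A few compounds are considered here, and "the series" means these few. Any claim that something is new, unique, unknown or untested is made for them only; others in the source may bear on it.

Three compounds have been measured in a functional assay on SK-MEL-2 cells (Homo sapiens) for inhibition, read by sulforhodamine B assay, with a stated time of 48 h; a higher number here means a weaker inhibitor of growth, a lower number a stronger inhibitor of growth:
compound 1 `COc1cc(-c2nn(-c3cccc(NC(=O)Nc4cc(C(F)(F)F)cc(C(F)(F)F)c4)c3)cc2-c2ccncc2)ccc1Cl` gives 1950 nM;
compound 2 `COc1cc(-c2nn(-c3cccc(NC(=O)Nc4ccc(Cl)c(Cl)c4)c3)cc2-c2ccncc2)ccc1Cl` gives 2350 nM;
compound 3 `O=C(Nc1cccc(-n2cc(-c3ccncc3)c(-c3ccc(Cl)c(O)c3)n2)c1)Nc1ccc(Cl)c(Cl)c1` gives 2640 nM.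

All three numbers lie within the usual scatter of one another, so none of these compounds can be set apart from the others on this evidence. The difference between the cores of compound 1 and compound 2 is not broken down here. Compound 3 is made from compound 2 by a single change, (hydrogen in place of methyl on an oxygen on an aromatic ring), and this gave a 1.1-fold higher number from compound 2 to compound 3 (0.05 log units; within the scatter). Compound 4 `O=C(Nc1cccc(-n2cc(-c3ccncc3)c(-c3ccc(Cl)c(O)c3)n2)c1)Nc1cc(C(F)(F)F)cc(C(F)(F)F)c1`, which has not yet been measured, is made from compound 1 by the same change, (hydrogen in place of methyl on an oxygen on an aromatic ring), at a place described in the same words as before, so the two changes are the same. Because the earlier step was a 1.1-fold higher number from compound 2 to compound 3 (0.05 log units; within the scatter), for compound 4 the corresponding step in this assay is expected to be of about the same small size, a 1.2-fold higher number from compound 1 to compound 4 (0.06 log units; within the scatter). On that basis compound 4 is estimated to give 2250 nM in this assay, with a likely range from 1000 nM to 5000 nM.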

Compound 4, concentration for total growth inhibition: 3030 nM
For compound 4 the middle estimate is 1.3-fold (0.13 log units) below the measured one; low and high end bracket the measured number.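

Replacing methoxy with hydroxy on the core of compound 1 gave a 1.6-fold higher number from compound 1 to compound 4 (0.19 log units; within the scatter) in this assay. Set beside the earlier step, the same change shows no detectable difference between the two cores, so in this small set it carries over from one core to the other: the same change on two cores in this assay, a 1.1-fold higher number (0.05 log units; within the scatter) from compound 2 to compound 3 and a 1.6-fold higher number (0.19 log units; within the scatter) from compound 1 to compound 4, 1.4-fold (0.14 log units) apart, within the scatter of two such steps

This agreement is limited, since both steps are too small to be told apart from repeat-measurement noise. It shows that swapping methyl for hydrogen on this oxygen produced no clear shift in growth inhibition on either core, but it does not show that the two steps are truly equal, or that the same would hold on a third core.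

The compounds shown carry only a methyl or a hydrogen on this oxygen, so it remains open whether a longer chain, or a chain ending in an amine or a carboxylic acid, would move the number beyond the scatter.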